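Compound 4: methoxymethyl in place of pyridin-4-yl

This account rests on a few compounds, and the source may have more. Where it says the series, first, only, none or still open, it means among the compounds named here.

In a functional assay on DU-145 cells (Homo sapiens) for antiproliferative activity, read by sulforhodamine B assay, with a stated time of 3 days (on this read-out lower numbers stand for stronger inhibition of growth and higher numbers for weaker inhibition of growth), compound 1 `O=C(Nc1cccc(Nc2ncc(F)c(Nc3ccc(F)cc3)n2)c1)c1cccc([N+](=O)[O-])c1` reads 12600 nM and compound 3 `O=C(Nc1cccc(Nc2ncc(F)c(Nc3ccc(F)cc3)n2)c1)c1ccncc1` reads 4330 nM as the lower of the two numbers available. Compound 2 `CN(C)c1ccc(C(=O)Nc2cccc(Nc3ncc(F)c(Nc4ccc(F)cc4)n3)c2)cc1` reads > 10000 nM as a limit of the assay and not a number. Compound 3 therefore stands lowest, with compound 1 its nearest neighbour.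

Compound 4 `COCC(=O)Nc1cccc(Nc2ncc(F)c(Nc3ccc(F)cc3)n2)c1` carries methoxymethyl in place of pyridin-4-yl on a carbonyl carbon.

Among the compounds with values here, the only step with two true numbers is a 2.9-fold lower number from compound 1 to compound 3 (0.46 log units; beyond the scatter) and it is modest. The other step into compound 3 is an at least 2.3-fold lower number from compound 2 to compound 3 (0.36 log units; beyond the scatter) and it rests on the limit. Within the data shown here, both replace one ring-bearing group with another on the same carbonyl carbon, and no measured compound has an open chain there, so they bear on the new change only indirectly. Their size suggests modest movement at this place. With compound 3 at the low end (4330 nM), a small rise is expected rather than a further fall. The expected step in this assay is a 1.5-fold higher number from compound 3 to compound 4 (0.18 log units; within the scatter) and it leaves the direction uncertain. Compound 4 is estimated at 6500 nM with an expected range from 2200 nM to 18000 nM in this series.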

Compound 4, concentration for 50% growth inhibition: 4460 nM
Compound 4: middle estimate off by 1.5-fold (0.16 log units), on the high side, within the range that was stated.
By their numbers in this assay, from the lowest: compounds 3 and 4 (each within the scatter of the next); then compound 1.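

In this assay, a 1.0-fold higher number from compound 3 to compound 4 (0.01 log units; within the scatter) shows that an open chain, methoxymethyl, can take the place of the pyridin-4-yl ring on this carbonyl carbon with no readable change, so among the compounds shown a ring at this place is not needed to reach the lowest numbers. The same chain also separates from the 3-nitrophenyl group, with a 2.8-fold lower number from compound 1 to compound 4 (0.45 log units; beyond the scatter), a step close in size to the one the pyridin-4-yl ring gave, so two very different groups now share the low end while the 3-nitrophenyl group stays higher. Against the 4-(dimethylamino)phenyl group the result is an at least 2.2-fold lower number from compound 2 to compound 4 (0.35 log units; beyond the scatter), and this step rests on a value for compound 2 that is a limit of the assay and not a number: the limit of > 10000 nM in this assay, at which 1 of the 4 values shown sits.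

On these data alone, whether the level shared by compound 3 and compound 4 holds for other groups on this carbonyl carbon stays open, for example a plain methyl, a longer ether chain, an aminomethyl group or a carboxylic acid. Also open, as far as these compounds go, is whether the higher readings belong to the substituents on the two phenyl rings or to the phenyl ring itself, which an unsubstituted phenyl would help to settle.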